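Aryl ether change from compound 1 to compound 4

A few compounds are considered here, and "the series" means these few. Any claim that something is new, unique, unknown or untested is made for them only; others in the source may bear on it.

Compound 1 `O=C(O)c1csc([C@H]2CC[C@@H]3[C@@H](COc4ccc(F)cc4)[C@H](O)C[C@@H]3O2)n1`: in an assay on HEK293 cells for agonist activity at prostaglandin E2 receptor EP2 subtype (Homo sapiens), read by a beta-galactosidase reporter and beta-arrestin recruitment, with a stated time of 90 min (a lower number here means that less compound is needed, a higher number that more compound is needed for the effect), compound 1 gives > 10000 nM.
Compound 2 `O=C(O)c1csc([C@H]2CC[C@@H]3[C@@H](/C=C/COc4ccccc4)[C@H](O)C[C@@H]3O2)n1`: compound 2 gives > 10000 nM.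
Compound 3 `O=C(O)c1csc([C@H]2CC[C@@H]3[C@@H](CCCOc4ccccc4)[C@H](O)C[C@@H]3O2)n1`: compound 3 gives > 10000 nM.

The value of compound 1 is a limit of the assay, not a number. The value of compound 2 is likewise a limit. The value of compound 3 is likewise a limit. All three sit at the same limit (the limit of > 10000 nM in this assay, at which 3 of the 3 values shown sit), so compound 1 stands nowhere readable among them. For the measured compounds named here, the only step connecting measured compounds, a step that the two limits leave unreadable from compound 1 to compound 3, cannot be read in size or direction. Compound 4 `O=C(O)c1csc([C@H]2CC[C@@H]3[C@@H](COc4ccccc4C(F)(F)F)[C@H](O)C[C@@H]3O2)n1` differs from compound 1 by 2-(trifluoromethyl)phenyl in place of 4-fluorophenyl on an oxygen on a saturated carbon. Going by the values given here, no measured step bears readably on this change, and the measured compounds give no footing for a direction. Compound 4 is expected to remain near the limit, estimated at 10000 nM with a range from 2000 nM to 40000 nM. The step this estimate implies, a number no higher from compound 1 to compound 4 (the limit leaves the size open), is expected to be no more than the scatter.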

Compound 4, half-maximal effective concentration: 11 nM
For compound 4 the middle estimate is 910-fold (2.96 log units) above the measured one; the whole stated range lies above it.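

In this assay the aryl group on the oxygen proves able to move the read-out, with 2-(trifluoromethyl)phenyl in place of 4-fluorophenyl giving an at least 900-fold lower number from compound 1 to compound 4 (2.95 log units; beyond the scatter) in this single change. The value of compound 1 is a limit, so the size of this step is a floor, and the step from compound 1 to compound 3 cannot be read. Compound 4 is the only compound here with a value that is a number: the limit of > 10000 nM in this assay, at which 3 of the 4 values shown sit.

From the compounds shown here alone, whether the step belongs to the trifluoromethyl group itself remains open, as a 2-chlorophenyl or 2-cyanophenyl ether would test. Also open, going by these compounds, is whether 2-(trifluoromethyl)phenyl keeps this value on the longer chain of compound 3.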